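A Benzyl Ester in Place of a Methyl Ester

The source may report more compounds than this note shows. Statements on the series, on what has been measured and on what is new or still open speak of the compounds shown alone.

Compound 1 `COC(=O)/C=C/c1cccc(N(Cc2ccc(/C=C/c3cccc(F)c3)cc2)C(=O)C2CCCCC2)c1` gives 86 nM in an assay on isolated protein with Bile acid receptor (Homo sapiens) as the target; on this read-out higher numbers stand for an effect only at larger amounts of compound and lower numbers for an effect already at smaller amounts.
Compound 2 `COC(=O)/C=C/c1cccc(N(Cc2ccc(Br)cc2)C(=O)C2CCCCC2)c1` gives > 1000 nM in this assay, which is a limit of the assay and not a number.
Compound 3 `COC(=O)/C=C/c1ccc(CN(C(=O)C2CCCCC2)c2cccc(/C=C/C(=O)OC)c2)cc1` gives > 1000 nM in this assay, again a limit of the assay.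

Compound 3 therefore stands at the edge of what this assay can resolve, at the limit of > 1000 nM in this assay, at which 2 of the 3 values shown sit. Only compound 1 yields a number, and the change from it to compound 3 cost an at least 11-fold higher number from compound 1 to compound 3 (1.06 log units; beyond the scatter).

Compound 4 `COC(=O)/C=C/c1cccc(N(Cc2ccc(/C=C/C(=O)OCc3ccccc3)cc2)C(=O)C2CCCCC2)c1` differs from compound 3 by phenyl in place of hydrogen on a saturated chain carbon bound to an oxygen next to a carbonyl group; the methoxycarbonyl of compound 3 becomes a benzyloxycarbonyl.

Within the data shown here, two measured steps touch the same end of the molecule. The step of an at least 11-fold higher number from compound 1 to compound 3 (1.06 log units; beyond the scatter) removed the 3-fluorophenyl from the double-bonded chain carbon and set a methoxycarbonyl there. The step of an at least 11-fold higher number from compound 1 to compound 2 (1.06 log units; beyond the scatter) put a bromo in place of the whole 2-(3-fluorophenyl)ethenyl. Both were large losses. Among the measured compounds shown here, compound 4 returns a phenyl, but on the ester, one step further out, and no measured pair tests a change at that spot. Whether an aromatic ring there brings back any of what compound 1 had is open, and since compound 3 sits at a limit, even the direction of a step that the limit leaves unreadable from compound 3 to compound 4 is only an expectation. Compound 4 is estimated at 1200 nM, with a range from 250 nM to 6000 nM.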

Compound 4, half-maximal effective concentration: > 1000 nM
Compound 4: no number, only a limit (the forecaster's own chance of this, stated with the estimate: 55%); the middle value lies beyond the limit too.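

In this assay compound 4 gives > 1000 nM, which is a limit of the assay and not a number. Set against the only compound with a readable value, the change is an at least 11-fold higher number from compound 1 to compound 4 (1.06 log units; beyond the scatter). An aromatic ring alone is therefore not enough at this end of the molecule: the phenyl of compound 4, carried on the ester as a benzyloxycarbonyl, does not give a readable value as the 3-fluorophenyl on a double-bonded chain carbon does in compound 1, and the steps to compound 4 from compound 2 and compound 3 cannot be read, leaving most of this small set at one limit: the limit of > 1000 nM in this assay, at which 3 of the 4 values shown sit.

On these data alone, how far compound 2, compound 3 and compound 4 each lie past that limit stays unknown, so methoxycarbonyl and benzyloxycarbonyl cannot be ranked against each other. Also open, as far as these compounds go, is whether a carboxylic acid in place of the ester, or an amine or a longer chain carrying the phenyl at this end, would return a readable value in this assay, and whether the fluoro group of compound 1 plays any part in its value.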